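This account rests on a few compounds, and the source may have more. Where it says the series, first, only, none or still open, it means among the compounds named here.

Working notes on the series. Compound 1 `O=C1C2=C(C(=O)c3ncccc31)C1(CS2)NC(=O)N(c2ccc(Cl)cc2)C1=O` is the reference point of this set. In a functional assay on SF-268 cells (Homo sapiens) for antiproliferative activity, read by MTT assay, with a stated time of 96 h (a lower number here means a stronger inhibitor, a higher number a weaker inhibitor), compound 1 gives 580 nM, and the only companion so far is compound 2 `CN(C)c1ccc(N2C(=O)NC3(CSC4=C3C(=O)c3ncccc3C4=O)C2=O)cc1`, which in this assay gives 950 nM. The two are linked by one change, dimethylamino in place of chloro on an aromatic carbon, which produced a 1.6-fold higher number from compound 1 to compound 2 (0.21 log units; within the scatter); on these two numbers compound 1 and compound 2 cannot be separated.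

Compound 3 `CC(C)(C)c1ccc(N2C(=O)NC3(CSC4=C3C(=O)c3ncccc3C4=O)C2=O)cc1` is not yet measured. It differs from compound 1 by tert-butyl in place of chloro on an aromatic carbon. Within the data shown here, the only measured step that bears on this is the exchange at the same aromatic carbon from compound 1 to compound 2, which stayed within the scatter. With no other guidance, a step of similar size is expected from compound 1 to compound 3, that is, no change beyond the scatter, a 1.1-fold higher number from compound 1 to compound 3 (0.05 log units; within the scatter). Compound 3 is therefore expected to give about 650 nM in this assay, with a range of 250 nM to 1700 nM.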

Compound 3, half-maximal inhibitory concentration: 500 nM
Compound 3: middle estimate off by 1.3-fold (0.11 log units), on the high side, and the stated range covers the measured number.
By their numbers in this assay, from the lowest: compounds 3, 1 and 2 (each within the scatter of the next).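

Working from this assay, tert-butyl now joins chloro and dimethylamino at this aromatic carbon, para to a large group: the exchange gives a 1.2-fold lower number from compound 1 to compound 3 (0.06 log units; within the scatter) and, measured against the other group, a 1.9-fold lower number from compound 2 to compound 3 (0.28 log units; within the scatter) in the same comparison. Four heavy atoms in place of one therefore leave the number within the scatter, and the three compounds cannot be separated, so this position has so far shown no response to the groups placed on it. Nothing measured here accounts for that result.

From the compounds shown here alone, whether a carboxylic acid, a primary amine or a longer alkyl chain at this carbon would move the number beyond the scatter remains open. Also open, going by these compounds, is how the number responds to any change away from this carbon, such as replacing the amide hydrogen of the shared core with a methyl group.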